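The source may report more compounds than this note shows. Statements on the series, on what has been measured and on what is new or still open speak of the compounds shown alone.

Measured in a physicochemical assay for lipophilicity, in phosphate buffer, measured as octanol-water partition; on this read-out higher numbers stand for higher lipophilicity and lower numbers for lower lipophilicity:
compound 1, `CCCc1nc2ccccc2c(=O)n1/N=C/c1ccc(Oc2ccc(Br)cc2)cc1`: 5.88
compound 2, `CCCc1nc2ccccc2c(=O)n1/N=C/c1ccc(Oc2ccc3ccccc3c2)cc1`: 6.12
compound 3, `Cc1nc2ccccc2c(=O)n1/N=C/c1ccc(Oc2ccc([N+](=O)[O-])cc2)cc1`: 4.01

Compound 2 stands highest of the three numbers; compound 1 lies close to it, as a number 0.24 log units higher from compound 1 to compound 2 (within the scatter) is within the scatter, while compound 3 lies far lower. Compound 4, `O=c1c2ccccc2nc(-c2ccccc2)n1/N=C/c1ccc(Oc2ccc3ccccc3c2)cc1`, differs from compound 2 by phenyl in place of propyl on an aromatic carbon. Among the measured compounds shown here, no measured step covers this exchange: the only step on record, a number 0.24 log units higher from compound 1 to compound 2 (within the scatter), concerns another place, and compound 3 differs from the others in two places, so it gives no guide. A small upward step, at about the edge of the scatter, is expected in this assay. Compound 4 is expected to give 6.4, between 5.9 and 6.9. The expected step is therefore a number 0.28 log units higher from compound 2 to compound 4 (within the scatter).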

Compound 4, partition coefficient: 6.53
Compound 4: the middle estimate sits 0.13 log units below what was measured; the measured number falls inside the stated range.
By their numbers in this assay, from the lowest: compound 3; then compounds 1 and 2 (each within the scatter of the next); then compound 4.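

In this assay the place between two ring nitrogen atoms can shift the number: phenyl in place of propyl gives a number 0.41 log units higher from compound 2 to compound 4 (beyond the scatter) as a modest step. Among the compounds shown here, the one earlier step, a number 0.24 log units higher from compound 1 to compound 2 (within the scatter) at another place, stayed within the scatter and said nothing about this position. Nothing on record explains the new step.

Only propyl and phenyl can be compared directly at this position. From the compounds shown here alone, how an amine, a carboxylic acid or a longer chain would behave here remains open.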